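Replacing a benzoyl ester with a methylbenzyl ether

The source may hold more compounds than are shown below. What is called first, only, known or untested is meant among the compounds shown, and "the series" means these compounds.

Measured so far:
Compound 1, `CCC1(Cc2ccccc2)OS(=O)(=O)C=C1OCc1ccc(C(F)(F)F)cc1`: in an ADME assay on HEL cells (Homo sapiens) for cytotoxicity, with a stated time of 3 days (a higher number here means that more compound is tolerated, a lower number that less compound is tolerated), compound 1 gives 99000 nM.
Compound 2, `CCC1(Cc2ccccc2)OS(=O)(=O)C=C1OC(=O)c1ccccc1`: in this assay compound 2 gives only a limit, > 200000 nM.

Compound 2 therefore stands at the top of the two results, at the limit of > 200000 nM in this assay, at which 1 of the 2 values shown sits, so its true value is not known as a number. Compound 1 carries a trifluoromethylbenzyl ether at the same oxygen and gives a number within the measured range.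

The unmeasured compound 3, `CCC1(Cc2ccccc2)OS(=O)(=O)C=C1OCc1ccc(C)cc1`, differs from compound 2 by 4-methylbenzyl in place of benzoyl on an oxygen on an unsaturated carbon. Going by the values given here, no step between measured compounds is available for this change, so its size is uncertain; the expected direction is a modest fall in tolerated concentration, of the size an at least 1.6-fold lower number from compound 2 to compound 3 (0.22 log units; that floor lies within the scatter), because compound 1 with a related benzyl ether gives 99000 nM. Compound 3 is expected to give about 120000 nM, within 50000 nM to 250000 nM.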

Compound 3, half-maximal cytotoxic concentration: 41500 nM
Compound 3: the middle estimate sits 2.9-fold (0.46 log units) above what was measured, outside the stated range (below it).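

In this assay, 4-methylbenzyl in place of benzoyl on this oxygen gives an at least 4.8-fold lower number from compound 2 to compound 3 (0.68 log units; beyond the scatter), so the group here clearly affects how much compound the cells tolerate. That step has no upper size, since compound 2 gives only a limit: the limit of > 200000 nM in this assay, at which 1 of the 3 values shown sits. Within the benzyl ethers, the group on the aromatic ring matters as well, since methyl in place of trifluoromethyl on an aromatic carbon gives a 2.4-fold lower number from compound 1 to compound 3 (0.38 log units; beyond the scatter).

The compounds shown do not separate the loss of the benzoyl carbonyl from the presence of the methyl group in the step from the ester to the ether, and a plain benzyl ether would bear directly on that question. As far as these compounds go, it also remains open how a chlorine atom or a carboxylic acid on that aromatic ring would shift the tolerated concentration.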